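A Sulfonamide Series With No Measured Inhibitor Yet

A few compounds are considered here, and "the series" means these few. Any claim that something is new, unique, unknown or untested is made for them only; others in the source may bear on it.

Among the compounds with values here, the three compounds measured so far share a sulfonamide joined to a two-ring aromatic core; they are compound 1 `O=S(=O)(Nc1ccc(-c2nc3ccccc3o2)cc1)c1ccc(Cl)c(C(F)(F)F)c1`, compound 2 `O=S(=O)(Nc1ccc(-c2nc3ccccc3o2)cc1)c1ccccc1Cl` and compound 3 `O=S(=O)(Nc1ccc2oc(-c3ccccc3)nc2c1)c1cccc(Cl)c1`. Each was tested in an assay on isolated protein for inhibition of malate dehydrogenase, mitochondrial (Sus scrofa), with stated times of 45 min and 30 min; a lower number here means a stronger inhibitor, a higher number a weaker inhibitor. Compound 1 gives > 63000 nM, which is a limit of the assay and not a number. Compound 2 gives > 63000 nM, again a limit. Compound 3 gives > 63000 nM, also a limit. Compound 2 therefore stands where every measured compound stands, at the limit of > 63000 nM in this assay, at which 3 of the 3 values shown sit. Within the data shown here, no step between measured compounds can be sized, since none of them yields a number.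

Compound 4 `COc1cccc(S(=O)(=O)Nc2ccc(-c3nc4ccccc4o3)cc2)c1` has not yet been measured. It differs from compound 2 in a single place: 3-methoxyphenyl in place of 2-chlorophenyl on a sulfonyl sulfur. Among the measured compounds shown here, nothing among the measured values points to a gain from this change, so the expected step that the limit leaves unreadable from compound 2 to compound 4 is none beyond the scatter. Compound 4 is thus expected to give 100000 nM in this assay, with a range from 30000 nM to 300000 nM, and most likely to be reported once more only as a limit.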

Compound 4, half-maximal inhibitory concentration: > 63000 nM
Compound 4 was reported as a limit (the forecaster's own chance of this, stated with the estimate: 85%); the middle value lies beyond the limit too.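

Compound 2 and compound 4 are both reported only as limits, so the step between them cannot be read: the limit of > 63000 nM in this assay, at which 4 of the 4 values shown sit.

The compounds shown leave open whether any change to this sulfonamide series would yield an actual number rather than another limit.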